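Trading a methoxy for hydrogen on compound 2

This account rests on a few compounds, and the source may have more. Where it says the series, first, only, none or still open, it means among the compounds named here.

In a functional assay on HepG2 cells (Homo sapiens) for cytotoxicity, read by sulforhodamine B assay, with a stated time of 48 h (on this read-out lower numbers stand for stronger inhibition and higher numbers for weaker inhibition), compound 1 `COc1ccc(/C=C/C(=O)c2ccc(NC(C)=O)c(-c3ccc(F)cc3)c2)cc1OC` gives 5630 nM, and compound 2 `COc1cc(/C=C/C(=O)c2ccc(N)c(-c3ccc(F)cc3)c2)cc(OC)c1OC` gives 4210 nM. These two values lie within the scatter of each other, so compound 2 stands level with compound 1 on the numbers at hand, and neither can be ranked over the other.

Compound 3 `COc1ccc(/C=C/C(=O)c2ccc(N)c(-c3ccc(F)cc3)c2)cc1OC` departs from compound 2 by a single change, hydrogen in place of methoxy on an aromatic carbon, ortho to a methoxy group and meta to a large group. Within the data shown here, no measured pair shows this change on its own, so the data give no direct guide to its size. Among the measured compounds shown here, the only numbers available, compound 1 at 5630 nM and compound 2 at 4210 nM, sit close together, and in this assay no step beyond the scatter is expected, with at most a slight drift toward weaker inhibition. The expected change is a 1.2-fold higher number from compound 2 to compound 3 (0.07 log units; within the scatter). For compound 3 the estimated value is 5000 nM, with an expected range from 2000 nM to 12000 nM.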

Compound 3, half-maximal inhibitory concentration: 3780 nM
Estimate against measurement, compound 3: 1.3-fold (0.12 log units) above; the measured number falls inside the stated range.
By their numbers in this assay, from the lowest: compounds 3, 2 and 1 (each within the scatter of the next).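

In this assay, among these compounds, hydrogen in place of methoxy on an aromatic carbon, ortho to a methoxy group and meta to a large group, gives a 1.1-fold lower number from compound 2 to compound 3 (0.05 log units; within the scatter), the first direct reading of this change, and it shows that the methoxy group at this position can be exchanged for hydrogen with no difference beyond the scatter in this read-out. Among the compounds shown here, compound 3 also provides a first reading at a second place, since hydrogen in place of acetyl on a nitrogen on an aromatic ring gives a 1.5-fold lower number from compound 1 to compound 3 (0.17 log units; within the scatter), so that change too stays inside the scatter, and all three compounds remain level on these numbers. No measurement offered here accounts for either result, which therefore stand as observations only.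

The compounds shown leave open whether a hydroxyl group, a chlorine atom or a longer chain such as ethoxy on this same aromatic carbon would separate from hydrogen and methoxy in this read-out. They also leave open whether a larger acyl group or a methanesulfonyl group on the nitrogen would give a value beyond the scatter of those seen for hydrogen and acetyl.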